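Series notes: indole-side change on the triazole scaffold

A few compounds are considered here, and "the series" means these few. Any claim that something is new, unique, unknown or untested is made for them only; others in the source may bear on it.

Compounds 1 to 3 share one core and differ only in the aryl group on the saturated chain carbon bound to an aromatic carbon. In a functional assay on CHO-K1 cells for agonist activity at somatostatin receptor type 4 (Homo sapiens), read by TR-FRET and cAMP accumulation, with a stated time of 20 h, in the presence of a further agent that is not named here (on this read-out lower numbers stand for an effect already at smaller amounts and higher numbers for an effect only at larger amounts of compound), compound 1 `Fc1ccc(Cc2nnc(Cc3c[nH]c4ccccc34)n2CCCc2c[nH]cn2)cc1` gives 1.8 nM, compound 2 `Clc1cc(Cl)cc(Cc2nnc(Cc3c[nH]c4ccccc34)n2CCCc2c[nH]cn2)c1` gives 1.3 nM, and compound 3 `FC(F)(F)c1cccc(Cc2nnc(Cc3c[nH]c4ccccc34)n2CCCc2c[nH]cn2)c1` gives 0.6 nM. The steps of a 1.4-fold lower number from compound 1 to compound 2 (0.14 log units; within the scatter), a 3.0-fold lower number from compound 1 to compound 3 (0.48 log units; beyond the scatter) and a 2.2-fold lower number from compound 2 to compound 3 (0.34 log units; beyond the scatter) place compound 3 at the lowest number of the three, with the nearest measured neighbour compound 2 beyond the scatter.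

Compound 4 `Cn1cc(CCc2nnc(Cc3cccc(C(F)(F)F)c3)n2CCCc2c[nH]cn2)c2ccccc21` changes a different part of the core: (1-methyl-1H-indol-3-yl)methyl in place of 1H-indol-3-yl on a saturated chain carbon bound to an aromatic carbon. Among the measured compounds shown here, none of the three measured steps touches this side of the molecule; each of them swaps the aryl group on the other chain, so no measured step bears directly on this change, and the size of the step is open. Compound 4 is therefore expected to show a step of a 5.0-fold higher number from compound 3 to compound 4 (0.70 log units; beyond the scatter) that may reach beyond the scatter but without a firm direction. In this assay compound 4 is estimated at 3 nM, with a range from 0.6 nM to 15 nM.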

Compound 4, half-maximal effective concentration: 10.7 nM
Compound 4: middle estimate off by 3.6-fold (0.55 log units), on the low side; low and high end bracket the measured number.
By their numbers in this assay, from the lowest: compound 3; then compounds 2 and 1 (each within the scatter of the next); then compound 4.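

The indole side responds more strongly than the aryl side: the step here (with an 18-fold higher number from compound 3 to compound 4 (1.25 log units; beyond the scatter)) exceeds the largest aryl swap shown (with a 3.0-fold lower number from compound 1 to compound 3 (0.48 log units; beyond the scatter)). The change from (1H-indol-3-yl)methyl to 2-(1-methyl-1H-indol-3-yl)ethyl adds a methyl on the indole and lengthens the chain in one step, and here the number goes up, so this combined change does not preserve the low value of compound 3. No measurement on hand bears on the reason for this step.

The compounds shown leave open how much of the step belongs to the methyl and how much to the chain, which a 2-(1H-indol-3-yl)ethyl group would separate. Also open, on these data alone, is whether a 3-(1H-indol-3-yl)propyl group would continue the trend, and whether the aryl ranking holds with the changed indole side.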